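Chloro for Isopropyl: A Step Beginning at the Limit

The compounds below may be only part of what the source reports. "The series", "measured", "known", "first", "only" and "open" are said of these compounds alone.

Of the compounds shown here, three have been tested in a functional assay on PC-3 cells (Homo sapiens) for antiproliferative activity, read by MTT assay, with a stated time of 72 h; on this read-out lower numbers stand for stronger inhibition and higher numbers for weaker inhibition. Compound 1 `Cc1ccc(C(C)C)c(OCCSC(=S)N[C@H]2CCOC2=O)c1` reached only the limit of the assay, > 64000 nM. Compound 3 `CC(=O)c1ccc(OCCSC(=S)N[C@H]2CCOC2=O)cc1` gave a measured value of 46900 nM. Compound 2 `CC(C)c1ccc(NCC(=O)N[C@H]2CCOC2=O)cc1` likewise reached only the limit, > 64000 nM. Compound 2 therefore stands among the values described by the limit of > 64000 nM in this assay, at which 2 of the 3 values shown sit; no number is known for it, and only compound 3 gives a value inside the range of this assay.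

Compound 4 `O=C(CNc1ccc(Cl)cc1)N[C@H]1CCOC1=O` has not yet been measured. It differs from compound 2 in a single place: chloro in place of isopropyl on an aromatic carbon. Among the measured compounds shown here, no step between measured compounds touches this position, so the data give no measured guide to what the exchange of isopropyl for chloro does to activity. With compound 2 sitting at the limit, any gain would have to be large before it became visible, and a loss could not be seen at all.

On this basis compound 4 is expected to remain weak, most likely again at or near the limit. For compound 4 the estimated value is 64000 nM, within a range from 25000 nM to 160000 nM. The expected step, in this assay, is a number no higher from compound 2 to compound 4 (the limit leaves the size open), that is, no change beyond the usual scatter.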

Compound 4, half-maximal inhibitory concentration: > 64000 nM
Compound 4 ended at the assay's limit (the forecaster's own chance of this, stated with the estimate: 65%); the middle value lies on the limit itself.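

Compound 2 and compound 4 both ended at a limit in this assay rather than at a number, so no step can be read between them for chloro in place of isopropyl: the limit of > 64000 nM in this assay, at which 3 of the 4 values shown sit.

The compounds shown leave open how strongly either compound acts, and whether this exchange on the aromatic carbon alters activity at all.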